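Aryl for methyl on the ring nitrogen: compound 4

The source may hold more compounds than are shown below. What is called first, only, known or untested is meant among the compounds shown, and "the series" means these compounds.

Working notes on the series. For the measured compounds named here, none of the measured compounds reaches a quantifiable maximal response in an assay on BaF3 cells with thrombopoietin receptor (Homo sapiens) as the target, read by a luciferase reporter; a higher number here means a larger maximal response, a lower number a smaller maximal response. Compound 1 `O=C(O)c1cccc2c(/N=N/c3c(O)cc(S(=O)(=O)O)c4ccccc34)c(O)ccc12` sits at a limit of this assay: in this assay compound 1 gives < 5%. Compound 2 `O=S(=O)(O)c1cc(O)c(NCc2c(O)ccc3ccccc23)c2ccccc12` sits at the same limit, and in this assay compound 2 gives < 5%. Compound 3 `Cc1[nH]n(C)c(=O)c1/N=N/c1c(O)cc(S(=O)(=O)O)c2ccccc12` is likewise at a limit, and in this assay compound 3 gives < 5%. Going by the values given here, compound 3 therefore stands at the limit of < 5% in this assay, at which 3 of the 3 values shown sit; no step between measured compounds can be read, and nothing in the numbers separates the three.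

Compound 4 `Cc1[nH]n(-c2ccc(I)cc2)c(=O)c1/N=N/c1c(O)cc(S(=O)(=O)O)c2ccccc12` differs from compound 3 by 4-iodophenyl in place of methyl on an aromatic nitrogen. Among the compounds with values here, with no measured step available, the size and direction of the step are open. The working expectation is that compound 4 stays close to compound 3, with the step from compound 3 to compound 4 estimated at a number at least 3 percentage points higher from compound 3 to compound 4 (that floor lies within the scatter). Compound 4 is estimated at 8%, with a range from 0% to 30%, and a considerable chance that this assay again reports only a limit.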

Compound 4, largest response reached (reported as efficacy), in percent of the reference or control that the assay uses: 81%
Compound 4: middle estimate off by 73 percentage points, on the low side; the measured number lies above the stated range.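

In this assay, 4-iodophenyl in place of methyl on an aromatic nitrogen gives a number at least 76 percentage points higher from compound 3 to compound 4 (beyond the scatter). The earlier compounds shown here offered no readable step, whereas this position shows that a single change on the shared core can carry a compound from an assay limit to a clearly measurable maximal response. Compound 4 is the only compound shown that stands clear of that limit, and the others remain at it: the limit of < 5% in this assay, at which 3 of the 4 values shown sit.

The two compounds compared here cannot separate the contribution of the aromatic ring from that of the iodine, and they do not show why the response rises. Going by these compounds, whether a plain phenyl, a 4-chlorophenyl or a phenyl bearing a carboxylic acid at this nitrogen would keep the response remains open.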